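Alkynyl isoquinoline and quinoline series: amino variant

This account rests on a few compounds, and the source may have more. Where it says the series, first, only, none or still open, it means among the compounds named here.

Measured so far:
compound 1, `Fc1cccc(F)c1C#Cc1ccc2nccc(Cl)c2c1` – 43.8%
compound 2, `Fc1cccc(F)c1C#Cc1cncc2ccccc12` – 16.5%

Of the compounds shown here, two carrying the same diaryl alkyne have been tested in a functional assay on LS174T cells (Homo sapiens) for inhibition, with a stated time of 4 days, tested at 1 uM; a lower number here means a weaker effect, a higher number a stronger effect of the compound at the concentration tested. Compound 1 gives 43.8%. Compound 2 gives 16.5%, the lowest of the two numbers; the gap to compound 1 lies beyond the usual scatter of such measurements, so compound 2 reads as the weaker of the pair in this assay. Going by the values given here, no pair of measured compounds differs in a single place, so no measured single-point step is available.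

The next compound, compound 3, `Nc1ncc(C#Cc2c(F)cccc2F)c2ccccc12`, is made from compound 2 by the change (amino in place of hydrogen on an aromatic carbon). The change puts the amino on the six-membered aromatic ring with one nitrogen, next to the ring nitrogen. Among the compounds with values here, nothing measured so far shows what an amino at this place does in this assay; the step is therefore expected to be modest, with a slight lean upward from the low value of compound 2, and it could also fall within the scatter. Compound 3 is estimated at 26%, within 6% to 50%; this means an expected step of a number 9.5 percentage points higher from compound 2 to compound 3 (within the scatter).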

Compound 3, a percentage reported as inhibition, at one concentration (the size of the read-out at that concentration, not a potency): 86.2%
Beside the measured number, compound 3's estimate is 60.2 percentage points below it, and the stated range ends below it.
By their numbers in this assay, from the lowest: compound 2; then compound 1; then compound 3.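

Amino in place of hydrogen is the first single-place change available in this series, and in this assay it gives a number 69.7 percentage points higher from compound 2 to compound 3 (beyond the scatter) on an otherwise unchanged structure. The step shows that this aromatic carbon, next to the ring nitrogen and para to a large group, is not a silent position: the low reading of compound 2 does not set a ceiling for the core it carries, and one substituent at this carbon is enough to move the read-out by a large margin. The data shown give no measured property or other independent result that would account for the size of this step.

From the compounds shown here alone, it remains open whether the step belongs to the amino group itself or would also appear with a methylamino, a dimethylamino, a hydroxyl or a methoxy group on the same carbon. Also open, going by these compounds, is whether amino at other carbons of the core would do the same, and whether the effect would carry over to the core of compound 1, since a single step on a single core cannot define a trend for the series.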